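The source may report more compounds than this note shows. Statements on the series, on what has been measured and on what is new or still open speak of the compounds shown alone.

Three compounds were examined in a functional assay on MIA PaCa-2 cells (Homo sapiens), read by MTT assay, with a stated time of 72 h; on this read-out higher numbers stand for weaker inhibition and lower numbers for stronger inhibition. Compound 1 `COc1cc(NC(C)CCCNC(=O)NCC2CCCCC2)c2ncccc2c1` gives 60000 nM, compound 2 `COc1cc(NC(C)CCCNC(=O)NCc2ccccc2)c2ncccc2c1` gives 21000 nM, and compound 3 `COc1cc(NC(C)CCCNC(=O)N(C2CCCCC2)C2CCCCC2)c2ncccc2c1` gives 17000 nM. Compound 3 holds the lowest of the three numbers, although its gap to compound 2 lies within the scatter, so these two cannot be ordered; only compound 1 stands clearly apart. Within the data shown here, the sole measured step, a 2.9-fold lower number from compound 1 to compound 2 (0.46 log units; beyond the scatter), concerns a different site and does not test the present change. Compound 4 `COc1cc(NC(C)CCCNC(=O)NC2CCCCC2)c2ncccc2c1` differs from compound 3 by hydrogen in place of cyclohexyl on an amide-type nitrogen. Since compound 1 sits well above compound 3, a weakening is expected, and the expected step is a 1.8-fold higher number from compound 3 to compound 4 (0.25 log units; within the scatter). Compound 4 is therefore estimated at 30000 nM, with a range of 12000 nM to 75000 nM.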

Compound 4, half-maximal inhibitory concentration: 38000 nM
Beside the measured number, compound 4's estimate is 1.3-fold (0.10 log units) below it; low and high end bracket the measured number.
By their numbers in this assay, from the lowest: compounds 3, 2, 4 and 1 (each within the scatter of the next, the first and the last beyond it).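

Hydrogen in place of cyclohexyl on the amide-type nitrogen gives a 2.2-fold higher number from compound 3 to compound 4 (0.35 log units; beyond the scatter) in this assay and is the first reading at this site, showing that the second cyclohexyl on that nitrogen makes a measurable, if modest, difference. By contrast, a 1.8-fold higher number from compound 2 to compound 4 (0.26 log units; within the scatter) and a 1.6-fold lower number from compound 1 to compound 4 (0.20 log units; within the scatter) both stay within the scatter, so cyclohexyl on this nitrogen cannot be told apart from benzyl or cyclohexylmethyl. Going by these compounds, whether methyl in place of the remaining amide hydrogen, or an amine on the cyclohexyl ring, would shift the number stays open. No evidence at hand accounts for the step at this nitrogen.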